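The compounds below may be only part of what the source reports. "The series", "measured", "known", "first", "only" and "open" are said of these compounds alone.

Measured in a functional assay on PC-3 cells (Homo sapiens) for cytotoxicity, read by WST assay, with a stated time of 72 h; on this read-out lower numbers stand for stronger inhibition and higher numbers for weaker inhibition:
- compound 1 `CCOc1ccc(C2(c3ccc(O)cc3)C(=O)Nc3c2ccc(F)c3F)cc1`: 24 nM
- compound 2 `O=C1Nc2c(ccc(F)c2F)C1(c1ccc(O)cc1)c1ccc(F)c(F)c1`: 19 nM
- compound 3 `O=C1Nc2c(ccc(F)c2F)C1(c1ccc(O)cc1)c1cccs1`: 0.3 nM

Compound 3 has the lowest number of the three, and both gaps are large: a 63-fold lower number from compound 2 to compound 3 (1.80 log units; beyond the scatter) and an 80-fold lower number from compound 1 to compound 3 (1.90 log units; beyond the scatter). By contrast, a 1.3-fold lower number from compound 1 to compound 2 (0.10 log units; within the scatter), so exchanging 4-ethoxyphenyl for 3,4-difluorophenyl gives no separation.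

Compound 4 `O=C1Nc2c(ccc(F)c2F)C1(c1ccc(O)cc1)C1CCCCCCC1` has cyclooctyl in place of thiophen-2-yl on a saturated ring carbon. Among the measured compounds shown here, no measured compound carries a non-aromatic ring at this carbon, so the evidence is indirect. The closest guide is that both other groups measured here sit well above compound 3, as a 63-fold lower number from compound 2 to compound 3 (1.80 log units; beyond the scatter) shows. A move to a higher number in this assay, beyond the scatter, is therefore expected, probably ending near compound 2 or somewhat under it. The expected size is a 27-fold higher number from compound 3 to compound 4 (1.43 log units; beyond the scatter). For compound 4 the estimated value is 8 nM, with an expected range of 1 nM to 60 nM.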

Compound 4, half-maximal inhibitory concentration: > 1000 nM
Compound 4 gave a limit, no number; the forecaster's own chance of this, stated with the estimate: 3%; middle value at least 120-fold (2.09 log units) away from the limit.
By their numbers in this assay, from the lowest: compound 3; then compounds 2 and 1 (each within the scatter of the next). At a limit, above all of these: compound 4.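

In this assay compound 4 gives a limit, not a number: the limit of > 1000 nM in this assay, at which 1 of the 4 values shown sits.

Among the compounds shown here, the saturated ring carbon therefore does not accept every ring: the earlier compounds carried only aromatic groups there and all gave measured values, whereas cyclooctyl gives an at least 3300-fold higher number from compound 3 to compound 4 (3.52 log units; beyond the scatter), an at least 52-fold higher number from compound 2 to compound 4 (1.72 log units; beyond the scatter) and an at least 41-fold higher number from compound 1 to compound 4 (1.61 log units; beyond the scatter). On these data alone, each of these steps is bounded by the limit, so its true size remains unknown, but all three lie beyond the scatter and the change from thiophen-2-yl is the largest of them.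

The compounds shown do not separate the absence of an aromatic ring from the size of the entering ring, and cyclopentyl or cyclohexyl at this carbon would bear on that. Also open, as far as these compounds go, is how an amine or a carboxylic acid on the ring at this carbon would read.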